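The compounds below may be only part of what the source reports. "The series", "measured", "known", "first", "only" and "open" are said of these compounds alone.

Measured in a functional assay on U-373MG ATCC cells for inhibition, with U373 MG (Homo sapiens) as the target, read by MTT assay, with a stated time of 7 days; on this read-out lower numbers stand for stronger inhibition of growth and higher numbers for weaker inhibition of growth:
- Compound 1 `NC(=O)c1ncn2c(=O)n(Cc3ccccc3)nnc12`: > 50000 nM
- Compound 2 `C[C@H](c1ccccc1)n1nnc2c(C(N)=O)ncn2c1=O`: > 50000 nM

Both entries are limits of the assay and not numbers. Compound 2 thus stands only at a limit, > 50000 nM, and gives no number to start from. Compound 3 `C[C@@H](c1ccccc1)n1nnc2c(C(N)=O)ncn2c1=O` has yet to be measured in this assay. The change from compound 2 is this: the two compounds have the same atoms and bonds and differ only in configuration as drawn: 1 of 1 stereo elements differ; a stereocentre at a saturated chain carbon is drawn R in compound 2 and S in compound 3. Among the compounds with values here, the one measured step that bears on it is a step that the two limits leave unreadable from compound 1 to compound 2, and it concerns the methyl rather than the configuration. The evidence amounts to the limit of > 50000 nM in this assay, at which 2 of the 2 values shown sit. Neither compound 1 nor compound 2 shows any growth inhibition that can be put as a number, so no step beyond the scatter is expected, in either direction. The expected step is a step that the limit leaves unreadable from compound 2 to compound 3. Compound 3 is estimated at 60000 nM, with an expected range of 30000 nM to 100000 nM, and most likely will again be reported only as a limit.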

Compound 3, concentration for 50% growth inhibition: > 50000 nM
Compound 3: only a limit was reported (the forecaster's own chance of this, stated with the estimate: 85%); the middle value does not contradict the limit.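

No step can be read among compound 1, compound 2 and compound 3 in this assay: the limit of > 50000 nM in this assay, at which 3 of the 3 values shown sit.

The compounds shown leave open whether the methyl or the configuration at the stereocentre has any bearing on growth inhibition, and which change to the shared core would give a readable value.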